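The compounds below may be only part of what the source reports. "The series", "measured", "known", "first", "only" and "open" are said of these compounds alone.

Measured so far:
Compound 1 `COc1ccccc1C(=O)Nc1ccc(Sc2nc3ccccc3s2)cc1`: in an assay on isolated protein for inhibition of thiosulfate sulfurtransferase (Homo sapiens), with a stated time of 60 min, in the absence of a further agent (a lower number here means a stronger inhibitor, a higher number a weaker inhibitor), compound 1 gives > 100000 nM, which is a limit of the assay and not a number.
Compound 2 `COc1c(Br)cccc1C(=O)Nc1ccc(Sc2nc3ccccc3s2)cc1`: in this assay compound 2 gives > 100000 nM, again a limit and not a number.

Compound 2 thus stands only at a limit; nothing measured places it at a definite strength. Among the compounds with values here, the one measured step, a step that the two limits leave unreadable from compound 1 to compound 2, runs between two limits and its size cannot be read, because both values sit at the limit of > 100000 nM in this assay, at which 2 of the 2 values shown sit. The step now followed goes from compound 2 to compound 3 `O=C(Nc1ccc(Sc2nc3ccccc3s2)cc1)c1cccc(Br)c1O`, which is hydrogen in place of methyl on an oxygen on an aromatic ring. Within the data shown here, no measured step involves this kind of change, and the only step available gives no size at all. What is expected in this assay is therefore no readable movement away from the limit. Compound 3 is estimated at 100000 nM, with a range from 30000 nM to 300000 nM. That estimate implies a step of a number no higher from compound 2 to compound 3 (the limit leaves the size open), expected to lie within the scatter and most likely to come back once more as a limit rather than a number.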

Compound 3, half-maximal inhibitory concentration: > 100000 nM
Compound 3: a limit, no number (the forecaster's own chance of this, stated with the estimate: 70%); the middle value lies on the limit itself.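

No step can be read among compound 1, compound 2 and compound 3, because all three give a limit of the assay and not a number: the limit of > 100000 nM in this assay, at which 3 of the 3 values shown sit.

The compounds shown leave open whether the bromo or the change from methoxy to hydroxy alters strength at all in this assay, and which structure would give a measurable number.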